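One more chain carbon toward the terminal group

This account rests on a few compounds, and the source may have more. Where it says the series, first, only, none or still open, it means among the compounds named here.

Compound 2 `CN(C)C(=O)c1cc2cnc(Nc3ccc(S(=O)(=O)NCCCCN=C=S)cc3)nc2n1C1CCCC1` gives 39.4% in a functional assay on A549 cells (Homo sapiens) for inhibition, read by CCK-8 assay, with a stated time of 72 h, tested at 1 uM (a lower number here means a weaker effect, a higher number a stronger effect of the compound at the concentration tested), the lower of the two numbers at hand, while compound 1 `CN(C)C(=O)c1cc2cnc(Nc3ccc(S(=O)(=O)NCCCN=C=S)cc3)nc2n1C1CCCC1` gives 58.9%. Compound 3 `CN(C)C(=O)c1cc2cnc(Nc3ccc(S(=O)(=O)NCCCCCN=C=S)cc3)nc2n1C1CCCC1` differs from compound 2 by a group of 4 heavy atoms (2 carbon, 1 nitrogen, 1 sulfur; no ring) in place of a group of 3 heavy atoms (1 carbon, 1 nitrogen, 1 sulfur; no ring), on a saturated chain carbon, four bonds along the chain from a sulfonamide nitrogen. Among the compounds with values here, the only measured step that bears on this is a number 19.5 percentage points lower from compound 1 to compound 2 (beyond the scatter), the same exchange made three bonds along the chain from a sulfonamide nitrogen. A further decline is therefore expected, probably of similar or somewhat smaller size, though a single prior step is a thin basis. Compound 3 is estimated at 27%, within 10% to 46%, meaning an expected step of a number 12.4 percentage points lower from compound 2 to compound 3 (beyond the scatter).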

Compound 3, a percentage reported as inhibition, at one concentration (the size of the read-out at that concentration, not a potency): 56.6%
Beside the measured number, compound 3's estimate is 29.6 percentage points below it; the whole stated range lies below it.
By their numbers in this assay, from the lowest: compound 2; then compounds 3 and 1 (each within the scatter of the next).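

In this assay, the further chain carbon, four bonds along the chain from a sulfonamide nitrogen, gives a number 17.2 percentage points higher from compound 2 to compound 3 (beyond the scatter) and so runs against the earlier step. The two-carbon extension gives a number 2.3 percentage points lower from compound 1 to compound 3 (within the scatter) and leaves these ends of the series level, so the three compounds show no steady decline with chain length, and compound 2 alone stands apart. Nothing at hand explains this dip at the middle chain length. Still open, as far as these compounds go, is how a longer chain would read in this assay. Also open, from the compounds shown here alone, is what a terminal amine would do in place of the present chain end.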